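Aryl ether swap on the coumarin-linked series

This account rests on a few compounds, and the source may have more. Where it says the series, first, only, none or still open, it means among the compounds named here.

Compound 2 `Cc1nn(C)c(Oc2ccc(Cl)cc2)c1/C=N\CCCCCCOc1cc2oc(=O)cc(C)c2cc1Cl` carries a 4-chlorophenyl group on the aryl oxygen of the shared core. For the measured compounds named here, in a functional assay on HepG2 cells (Homo sapiens) for antiproliferative activity, read by MTT assay, with a stated time of 72 h (on this read-out lower numbers stand for stronger inhibition and higher numbers for weaker inhibition), compound 2 gives 2960 nM, the only numeric value shown for the series. Compound 1 `Cc1nn(C)c(Oc2ccc(F)c(F)c2)c1/C=N\CCCCCCOc1cc2oc(=O)cc(C)c2cc1Cl` differs only in bearing 3,4-difluorophenyl there. In this assay compound 1 reaches only a limit of the assay, > 25000 nM. Going by the values given here, the one measured step is an at least 8.4-fold lower number from compound 1 to compound 2 (0.92 log units; beyond the scatter); its size is bounded by the limit of > 25000 nM in this assay, at which 1 of the 2 values shown sits, rather than by a number.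

Compound 3 `Cc1nn(C)c(Oc2ccccc2Br)c1/C=N\CCCCCCOc1cc2oc(=O)cc(C)c2cc1Cl` introduces (2-bromophenyl in place of 4-chlorophenyl on an oxygen on an aromatic ring). Among the compounds with values here, no measured pair exchanges a halogen for a different halogen, nor moves it about the ring, so the step from compound 1 to compound 2 speaks only in general terms: the aryl group on that oxygen matters for this assay, and the halogen pattern can shift the read-out beyond the scatter in either direction. Within the data shown here, with no direct precedent, the expected step from compound 2 to compound 3 is a 1.7-fold higher number from compound 2 to compound 3 (0.23 log units; within the scatter), a modest weakening with wide uncertainty. Compound 3 is therefore estimated at 5000 nM, within a range of 1500 nM to 25000 nM.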

Compound 3, half-maximal inhibitory concentration: 24200 nM
Beside the measured number, compound 3's estimate is 4.8-fold (0.68 log units) below it; low and high end bracket the measured number.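

The exchange of 4-chlorophenyl for 2-bromophenyl leaves the counts of heavy atoms, donors and acceptors alike, yet in this assay it gives an 8.2-fold higher number from compound 2 to compound 3 (0.91 log units; beyond the scatter), so a change that keeps these counts can still move the read-out beyond the scatter. With this step, compound 2 stands apart from both other compounds by steps beyond the scatter, which makes it the strongest of the three and shows that a single halogen on the phenyl ring does not by itself secure its number. The other new step, an at least 1.0-fold lower number from compound 1 to compound 3 (0.01 log units; that floor lies within the scatter), sets only a floor and leaves 2-bromophenyl and 3,4-difluorophenyl unordered, its far end being a limit of the assay and not a number: the limit of > 25000 nM in this assay, at which 1 of the 3 values shown sits.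

The halogen and its place on the ring change together in the step to compound 3, and no pair shown separates the two. Going by these compounds, what 2-chlorophenyl, 4-bromophenyl or plain phenyl would give on that oxygen stays open, as does whether an amine on the aryl ring would hold the number of compound 2.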